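Sulfonamide swap on the shared core of compound 1

The source may hold more compounds than are shown below. What is called first, only, known or untested is meant among the compounds shown, and "the series" means these compounds.

Among the compounds with values here, compound 1 `CCOC(=O)[C@@H]1CCCN(S(=O)(=O)c2ccc(S(=O)(=O)N3CCCCC3)cc2)C1` is the only member of the series with a numerical reading: in a functional assay on MIA PaCa-2 cells (Homo sapiens) for inhibition, read by MTT assay, with a stated time of 3 days (on this read-out lower numbers stand for stronger inhibition and higher numbers for weaker inhibition), compound 1 gives 1000 nM. Compound 2 `CCOC(=O)[C@@H]1CCCN(S(=O)(=O)c2ccc3cc(S(=O)(=O)N(CC)CC)ccc3c2)C1` has no number in this assay, only a limit, and compound 2 sits at > 3000 nM, which is the limit of > 3000 nM in this assay, at which 1 of the 2 values shown sits. Within the data shown here, no step between two measured compounds is available, so no measured step can be used to anchor the change. The step from compound 1 to compound 3 `CCOC(=O)[C@@H]1CCCN(S(=O)(=O)c2ccc(S(=O)(=O)N3CCOCC3)cc2)C1` is morpholin-4-yl in place of piperidin-1-yl on a sulfonyl sulfur. Compound 3 is expected to be close to compound 1, with a shift of a 1.5-fold higher number from compound 1 to compound 3 (0.18 log units; within the scatter), at most slightly toward weaker inhibition and not clearly beyond the scatter. In this assay compound 3 is estimated at 1500 nM, within a range from 500 nM to 5000 nM.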

Compound 3, half-maximal inhibitory concentration: 4100 nM
Estimate against measurement, compound 3: 2.7-fold (0.44 log units) below, within the range that was stated.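

Within the data shown here, the first measured step falls on the sulfonyl sulfur: in this assay, there is a 4.1-fold higher number from compound 1 to compound 3 (0.61 log units; beyond the scatter). The earlier compounds shown here offered no step at all, and this one shows that the ring on that sulfur is not a silent place on the shared core: with the ring size unchanged, morpholin-4-yl in place of piperidin-1-yl moves the reading beyond the scatter. Nothing measured here accounts for the size of that step.

On these data alone, whether the ring oxygen itself matters or any other change to this ring would do the same stays open, and a 4-methylpiperazin-1-yl or pyrrolidin-1-yl group on the same sulfur would help to separate the two. Compound 2 holds only a limit and adds no step: the limit of > 3000 nM in this assay, at which 1 of the 3 values shown sits.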